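Methoxy in place of hydrogen on the diene amide

The compounds below may be only part of what the source reports. "The series", "measured", "known", "first", "only" and "open" are said of these compounds alone.

Compound 3 `O=C(/C=C/C=C/c1ccccc1)N1CCCCC1` stands second highest of three in an assay for inhibition of Polyunsaturated fatty acid 5-lipoxygenase (Homo sapiens), read by spectrophotometry, tested at 20 uM (on this read-out higher numbers stand for more inhibition at the one concentration tested (going by the name of the read-out) and lower numbers for less inhibition), where compound 3 gives 36.3%; compound 2 `O=C(/C=C/C=C/c1ccc(F)cc1)N1CCCCC1` gives 48.7%, and compound 1 `CN(C)c1ccc(/C=C/C=C/C(=O)N2CCCCC2)cc1` gives 13.4%. Compound 4 `COc1ccc(/C=C/C=C/C(=O)N2CCCCC2)cc1` differs from compound 3 by methoxy in place of hydrogen on an aromatic carbon. Among the compounds with values here, two measured steps bear on this change: a number 22.9 percentage points higher from compound 1 to compound 3 (beyond the scatter), a modest rise when hydrogen took the place of dimethylamino, and a number 12.4 percentage points lower from compound 2 to compound 3 (beyond the scatter), a modest fall when hydrogen took the place of fluoro. A group entering in place of hydrogen on that aromatic carbon has thus gone either way, so the step of a number 8.3 percentage points lower from compound 3 to compound 4 (within the scatter) is expected to be small and more likely downward than upward. Compound 4 is estimated at 28% in this assay, with a range from 14% to 42%.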

Compound 4, a percentage reported as inhibition, at one concentration (the size of the read-out at that concentration, not a potency): 42.6%
Beside the measured number, compound 4's estimate is 14.6 percentage points below it; the measured number lies above the stated range.
By their numbers in this assay, from the lowest: compound 1; then compounds 3, 4 and 2 (each within the scatter of the next, the first and the last beyond it).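

In this assay methoxy on this aromatic carbon cannot be told apart from hydrogen or fluoro, with a number 6.3 percentage points higher from compound 3 to compound 4 (within the scatter) and a number 6.1 percentage points lower from compound 2 to compound 4 (within the scatter) as the two steps. With a number 29.2 percentage points higher from compound 1 to compound 4 (beyond the scatter) the low reading stays with dimethylamino and does not carry over to methoxy, so a group entering here need not lower the number. No evidence at hand explains why these two groups part. As far as these compounds go, whether a primary amine, a carboxylic acid or a longer alkoxy chain on this carbon would read like methoxy or like dimethylamino remains open.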